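A Urea Replaces a Hydroxypropyl Chain: Cytotoxicity Outlook

This account rests on a few compounds, and the source may have more. Where it says the series, first, only, none or still open, it means among the compounds named here.

Of the compounds shown here, three have so far been tested in an ADME assay on L6 cells (Rattus norvegicus) for cytotoxicity, read by resazurin assay, with a stated time of 70 h (a lower number here means a stronger inhibitor, a higher number a weaker inhibitor), all sharing one core. Compound 1, `COc1cc(NC(C)CCCNC(=O)/C=C/c2ccc(OC)c(OC)c2)c2ncccc2c1`, carries a 3,4-dimethoxyphenyl group on its double-bonded chain. Compound 1 returns only a limit of the assay, > 220000 nM, not a number. Compound 2, `COc1cc(NC(C)CCCNC(=O)/C=C/c2ccc(C(F)(F)F)cc2)c2ncccc2c1`, gives 160000 nM in this assay. Among the measured compounds shown here, the only measured step, an at least 1.3-fold lower number from compound 1 to compound 2 (0.13 log units; that floor lies within the scatter), rests on that limit, (the limit of > 220000 nM in this assay, at which 1 of the 3 values shown sits), and so shows no change that can be trusted beyond the scatter.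

Compound 3, `COc1cc(NC(C)CCCNC(=O)NCCCO)c2ncccc2c1`, has no result in this assay; for compound 3 the entry reads "not determined" (no result reported), so it stands nowhere on the numbers shown. Compound 4, `COc1cc(NC(C)CCCNC(=O)NNC(=O)Nc2ccc(Cl)cc2)c2ncccc2c1`, differs from it by one change: ((4-chlorophenyl)carbamoyl)amino in place of 3-hydroxypropyl on an amide-type nitrogen. For the measured compounds named here, no measured step involves either this kind of exchange or the amide-type nitrogen where it happens, so the single step from compound 1 to compound 2 bears on it only by showing where these compounds sit: in the region of weak inhibitors of cell growth. In this assay the value of compound 4 is therefore expected to lie near the two measured ones, with a real chance that only a limit is reported. Compound 4 is estimated at 120000 nM, within a range from 40000 nM to 250000 nM.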

Compound 4, half-maximal inhibitory concentration: 91900 nM
Compound 4: the middle estimate sits 1.3-fold (0.12 log units) above what was measured; measured number inside the range.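

In this assay, among the compounds shown here, compound 3 reads "not determined" (no result reported), so the exchange leading to compound 4 gives no step that can be read. The compounds shown leave open whether ((4-chlorophenyl)carbamoyl)amino in place of 3-hydroxypropyl on an amide-type nitrogen changes the number at all, and in which direction.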